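Moving the Chlorine: From Compound 2 to Compound 4

A few compounds are considered here, and "the series" means these few. Any claim that something is new, unique, unknown or untested is made for them only; others in the source may bear on it.

Three compounds have been measured in a functional assay; a higher number here means a weaker inhibitor, a lower number a stronger inhibitor:

Compound 1 `Fc1ccc2c(c1)CCC(c1nnc(-c3cn(Cc4c(F)cccc4F)nn3)o1)O2`: 23100 nM
Compound 2 `Fc1ccc2c(c1)CCC(c1nnc(-c3ccccc3Cl)o1)O2`: 40800 nM
Compound 3 `Fc1ccc2c(c1)CCC(c1nnc(-c3cc(F)c(F)c(F)c3F)o1)O2`: 29000 nM

Compound 2 stands at the highest of the three numbers, yet its gap to compound 3 and its gap to compound 1 both lie within the scatter, so no order can be read among these three. Compound 4 `Fc1ccc2c(c1)CCC(c1nnc(-c3ccc(Cl)cc3)o1)O2` differs from compound 2 by 4-chlorophenyl in place of 2-chlorophenyl on an aromatic carbon. For the measured compounds named here, no measured pair shows this change, so nothing in this assay speaks for a step beyond the scatter in either direction. Compound 4 is therefore expected near 35000 nM, with a range from 12000 nM to 100000 nM. That estimate amounts to a step of a 1.2-fold lower number from compound 2 to compound 4 (0.07 log units; within the scatter), which is expected to stay within the scatter.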

Compound 4, half-maximal inhibitory concentration: 17200 nM
Beside the measured number, compound 4's estimate is 2.0-fold (0.31 log units) above it, within the range that was stated.
By their numbers in this assay, from the lowest: compounds 4, 1, 3 and 2 (each within the scatter of the next, the first and the last beyond it).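

The earlier compounds shown here offered no comparison of a single change; in this assay, replacing 2-chlorophenyl with 4-chlorophenyl now gives a 2.4-fold lower number from compound 2 to compound 4 (0.38 log units; beyond the scatter), a modest step. The two groups carry the same atoms, joined differently, and the number still moves, so at this aromatic carbon the place of the chlorine on the phenyl ring counts, not only its presence.

From the compounds shown here alone, whether 3-chlorophenyl would follow, or whether a methoxy group or an amine could stand in for the chlorine of 4-chlorophenyl, remains open. Nothing available gives a reason for this step.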